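From E to Z at the double bond of compound 2

This account rests on a few compounds, and the source may have more. Where it says the series, first, only, none or still open, it means among the compounds named here.

In a functional assay on MCF7 cells (Homo sapiens) for cytotoxicity (on this read-out higher numbers stand for an effect only at larger amounts of compound and lower numbers for an effect already at smaller amounts), compound 1 (`COc1cc(/C=C/c2ccc(C(C)C)cc2)cc(OC)c1OC`) gives 18.4 uM, compound 2 (`CCOc1ccc(/C=C/c2cc(OC)c(OC)c(OC)c2)cc1`) gives 7.5 uM and compound 3 (`COc1cc(/C=C/c2ccc(SC)cc2)cc(OC)c1OC`) gives 5.9 uM. Two steps fix the place of compound 2 in this set: a 2.5-fold lower number from compound 1 to compound 2 (0.39 log units; beyond the scatter), and a 1.3-fold lower number from compound 2 to compound 3 (0.10 log units; within the scatter). It therefore stands clear of compound 1 but not of compound 3.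

Compound 4 (`CCOc1ccc(/C=C\c2cc(OC)c(OC)c(OC)c2)cc1`) is the next case: the two compounds have the same atoms and bonds and differ only in configuration as drawn: 1 of 1 stereo elements differ; a double bond is drawn E in compound 2 and Z in compound 4.

The remaining step, a 3.1-fold lower number from compound 1 to compound 3 (0.49 log units; beyond the scatter), also exchanges a group on an aromatic carbon, as the other two do. Within the data shown here, no measured pair differs at the double bond, so these steps give no direct size or direction for this change. They show only how far the three values spread in this assay. A lean towards a lower number is a judgement on the structural change alone, and the range is kept wide. The expected change is a 5.0-fold lower number from compound 2 to compound 4 (0.70 log units; beyond the scatter). Compound 4 is estimated at 1.5 uM, with an expected range of 0.05 uM to 12 uM.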

Compound 4, concentration for half-maximal effect: 9.6 uM
Beside the measured number, compound 4's estimate is 6.4-fold (0.81 log units) below it; measured number inside the range.
By their numbers in this assay, from the lowest: compounds 3, 2, 4 and 1 (each within the scatter of the next, the first and the last beyond it).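

In this assay, among these compounds, the double bond now has a direct reading, which none of the earlier steps gave, since all of them exchanged a group on an aromatic carbon: a 1.3-fold higher number from compound 2 to compound 4 (0.11 log units; within the scatter). For this ethoxy pair, the E and Z forms as drawn cannot be told apart on this read-out, so no preference for either configuration can be stated. The comparison is clean, and the step concerns one structural element only: the fact that compounds 2 and 4 differ only in the configuration as drawn.

On these data alone, whether a Z double bond reads the same with the isopropyl group of compound 1 or the methylsulfanyl group of compound 3 stays open. Also open, as far as these compounds go, is how either configuration reads with an amine or a longer chain in place of ethoxy on that aromatic carbon.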